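Nitro on the methoxyphenyl arm, carried to a second core

The compounds below may be only part of what the source reports. "The series", "measured", "known", "first", "only" and "open" are said of these compounds alone.

Of the compounds shown here, three have been measured in a functional assay on SGC-7901 cells (Homo sapiens) for antiproliferative activity, read by MTT assay, with a stated time of 72 h; on this read-out higher numbers stand for weaker inhibition and lower numbers for stronger inhibition. Compound 1 `CCOC(=O)c1cc(-c2cc(OC)c(OC)c(OC)c2)c(-c2ccc(OC)cc2)s1` gives 9760 nM. Compound 2 `CCOC(=O)c1cc(-c2cc(OC)c(OC)c(OC)c2)c(-c2ccc(OC)c([N+](=O)[O-])c2)s1` carries the change nitro in place of hydrogen on an aromatic carbon relative to compound 1; in this assay compound 2 gives 18100 nM, and the step is a 1.9-fold higher number from compound 1 to compound 2 (0.27 log units; within the scatter). Compound 3 `COc1ccc(-c2sccc2-c2cc(OC)c(OC)c(OC)c2)cc1` gives 5470 nM. Compound 3 and compound 1 differ only in the core, by hydrogen in place of ethoxycarbonyl on an aromatic carbon, and the step is a 1.8-fold lower number from compound 1 to compound 3 (0.25 log units; within the scatter). Compound 3 has the lowest number of the three, but its separation from compound 1 lies within the scatter, so no order between these two is claimed; only compound 2 stands apart from compound 3 beyond the scatter.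

Compound 4 `COc1ccc(-c2sccc2-c2cc(OC)c(OC)c(OC)c2)cc1[N+](=O)[O-]` is not yet measured in this assay. It differs from compound 3 by nitro in place of hydrogen on an aromatic carbon. The place of the change is the same, word for word, as between compound 1 and compound 2: on an aromatic carbon of a six-membered aromatic ring of carbon only, ortho to a methoxy group, meta to a large group. Only the core carrying the change differs, as already set out.

Among the measured compounds shown here, the expected step is a 1.8-fold higher number from compound 3 to compound 4 (0.26 log units; within the scatter), estimated from the one earlier instance because that instance gave a 1.9-fold higher number from compound 1 to compound 2 (0.27 log units; within the scatter). A single precedent is a thin basis, and that precedent itself lies within the scatter, so the range is kept wide. Compound 4 is expected to give 10000 nM, between 4000 nM and 25000 nM.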

Compound 4, half-maximal inhibitory concentration: 3310 nM
Beside the measured number, compound 4's estimate is 3.0-fold (0.48 log units) above it; measured number below the stated range.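

In this assay, nitro in place of hydrogen on an aromatic carbon gives a 1.7-fold lower number from compound 3 to compound 4 (0.22 log units; within the scatter), and this step does not match the one seen on the core of compound 1: the same change on two cores in this assay, a 1.9-fold higher number (0.27 log units; within the scatter) from compound 1 to compound 2 and a 1.7-fold lower number (0.22 log units; within the scatter) from compound 3 to compound 4, 3.1-fold (0.49 log units) apart, beyond the scatter of two such steps Read along the other edge of the same four compounds, hydrogen in place of ethoxycarbonyl on an aromatic carbon gives a 5.5-fold lower number from compound 2 to compound 4 (0.74 log units; beyond the scatter), and this step likewise does not match its counterpart: the same change on two cores in this assay, a 1.8-fold lower number (0.25 log units; within the scatter) from compound 1 to compound 3 and a 5.5-fold lower number (0.74 log units; beyond the scatter) from compound 2 to compound 4, 3.1-fold (0.49 log units) apart, beyond the scatter of two such steps The nitro step therefore does not carry unchanged from the core of compound 1 to the core of compound 3, but these two comparisons rest on the same four compounds and amount to a single observation, each nitro step taken alone lies within the scatter, and nothing here shows that nitro helps or harms on either core or why the steps part.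

The compounds shown leave open whether an amine or a halogen such as fluorine at the same place, ortho to a methoxy group, would show the same dependence on the core. They also leave open whether a carboxylic acid or an amide in place of ethoxycarbonyl would give a core on which the nitro step follows either of the two seen so far.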